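Swapping an isopropylamide for a pyrrolidine amide

The source may report more compounds than this note shows. Statements on the series, on what has been measured and on what is new or still open speak of the compounds shown alone.

Measured in a functional assay on A549 cells (Homo sapiens) for antiproliferative activity, read by CCK-8 assay, with a stated time of 48 h; a higher number here means a weaker inhibitor, a lower number a stronger inhibitor:
- Compound 1 `O=C(c1cc(Oc2ccc(/C=C/c3ccccn3)cc2)ccn1)N1CCCC1` gives 15600 nM
- Compound 2 `O=C(NCc1ccc(F)cc1)c1cc(Oc2ccc(/C=C/c3ccncc3)cc2)ccn1` gives 18200 nM
- Compound 3 `CC(C)NC(=O)c1cc(Oc2ccc(/C=C/c3ccncc3)cc2)ccn1` gives 20600 nM

Compound 3 holds the highest of the three numbers, yet all three sit within the scatter of one another, so no ordering among them can be claimed. Compound 4 `O=C(c1cc(Oc2ccc(/C=C/c3ccncc3)cc2)ccn1)N1CCCC1` is the next compound, and it differs from compound 3 in one place: pyrrolidin-1-yl in place of isopropylamino on a carbonyl carbon. Going by the values given here, the only measured step on the amide nitrogen, a 1.1-fold higher number from compound 2 to compound 3 (0.05 log units; within the scatter), stayed within the scatter. Compound 1 carries the same pyrrolidine amide as compound 4 but differs at a second site, so its value can only hint that this amide is tolerated. Compound 4 is therefore expected to show a 1.3-fold lower number from compound 3 to compound 4 (0.11 log units; within the scatter), nothing beyond the scatter. The estimate for compound 4 is 16000 nM, within 7000 nM to 36000 nM.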

Compound 4, half-maximal inhibitory concentration: 18600 nM
Compound 4: the middle estimate sits 1.2-fold (0.07 log units) below what was measured; the range from low to high includes it.
By their numbers in this assay, from the lowest: compounds 1, 2, 4 and 3 (each within the scatter of the next).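

In this assay, pyrrolidin-1-yl in place of isopropylamino gives a 1.1-fold lower number from compound 3 to compound 4 (0.04 log units; within the scatter) and so removes the hydrogen-bond donor and adds a ring on this carbonyl carbon with no difference beyond the scatter. Its exchange for (4-fluorobenzyl)amino gives a 1.0-fold higher number from compound 2 to compound 4 (0.01 log units; within the scatter) and pyridin-4-yl in place of pyridin-2-yl gives a 1.2-fold higher number from compound 1 to compound 4 (0.08 log units; within the scatter) so neither site separates these compounds. No measurement is available that would explain this lack of separation.

Still open, on these data alone, is whether a carboxylic acid or an amine-bearing longer chain on this carbonyl carbon would give a step beyond the scatter.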